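From a 3-hydroxyphenyl to a 4-aminophenyl group

A few compounds are considered here, and "the series" means these few. Any claim that something is new, unique, unknown or untested is made for them only; others in the source may bear on it.

In a functional assay on U2OS cells (Homo sapiens) for cytotoxicity, read by MTT assay, with a stated time of 48 h (on this read-out lower numbers stand for stronger inhibition and higher numbers for weaker inhibition), compound 1 `Fc1cccc(-c2nc(Nc3ccccc3Br)c3cc(F)ccc3n2)c1` gives > 50000 nM as a limit of the assay and not a number. In this assay, for the measured compounds named here, compound 2 `Oc1cccc(Nc2nc(-c3cccc(F)c3)nc3ccc(F)cc23)c1` gives 33300 nM and so holds the only true number so far, with compound 1 as its sole comparison. Going by the values given here, the one measured step is an at least 1.5-fold lower number from compound 1 to compound 2 (0.17 log units; that floor lies within the scatter) and it exchanges the group at the same place that changes next. With only a floor on its size, that step sets no firm scale for this place. Compound 3 `Nc1ccc(Nc2nc(-c3cccc(F)c3)nc3ccc(F)cc23)cc1` keeps the core of compound 2 and has 4-aminophenyl in place of 3-hydroxyphenyl on a nitrogen on an aromatic ring. Among the compounds with values here, the sole guide is compound 2 at 33300 nM and the step that leads to it, so only a small shift is anticipated, and no clear move beyond the scatter is foreseen. The expected step is a 1.3-fold lower number from compound 2 to compound 3 (0.12 log units; within the scatter) in this assay. Compound 3 is estimated at 25000 nM, with an expected range from 8000 nM to 50000 nM.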

Compound 3, half-maximal inhibitory concentration: 44200 nM
For compound 3 the middle estimate is 1.8-fold (0.25 log units) below the measured one; the range from low to high includes it.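

In this assay the exchange of 3-hydroxyphenyl for 4-aminophenyl on the nitrogen gives a 1.3-fold higher number from compound 2 to compound 3 (0.12 log units; within the scatter) and so leaves compound 2 and compound 3 indistinguishable on this read-out. Although this exchange alters both the ring atom that carries the hydrogen-bond donor and the name of its ring place, the cell read-out does not separate the two groups. The other step at this place reads an at least 1.1-fold lower number from compound 1 to compound 3 (0.05 log units; that floor lies within the scatter) as a floor only, and its true size stays unknown because one end of it is a limit of the assay and not a number: the limit of > 50000 nM in this assay, at which 1 of the 3 values shown sits.

The compounds shown do not separate the change of atom from the change of ring place, which a 3-aminophenyl or a 4-hydroxyphenyl group on the same nitrogen would address. They also leave open whether a different group here, such as a phenyl ring carrying a carboxylic acid or a longer chain in place of the ring, would give a step beyond the scatter.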